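The source may hold more compounds than are shown below. What is called first, only, known or untested is meant among the compounds shown, and "the series" means these compounds.

Measured compounds and their values:

Compound 1, `O=C1O[C@H]([C@@H](O)Cn2cc(CNS(=O)(=O)c3ccc(Cl)cc3F)nn2)C(OCc2ccccc2)=C1OCc1ccccc1`, 58200 nM
Compound 2, `C[Si](C)(C)c1cn(C[C@H](O)[C@H]2OC(=O)C(OCc3ccccc3)=C2OCc2ccccc2)nn1`, 52600 nM
Compound 3, `COc1ccc(-c2cn(C[C@H](O)[C@H]3OC(=O)C(OCc4ccccc4)=C3OCc3ccccc3)nn2)cc1`, 26000 nM

These three compounds were compared in a functional assay on CFPAC-1 cells (Homo sapiens) for antiproliferative activity, read by MTT assay, with a stated time of 72 h; a lower number here means a stronger inhibitor, a higher number a weaker inhibitor. Among the three numbers, compound 3 stands lowest. Its nearest neighbour is compound 2, and the step of a 2.0-fold lower number from compound 2 to compound 3 (0.31 log units; beyond the scatter) lies beyond the scatter. Within the data shown here, compound 1 gives the highest of the three numbers in this assay; its value and that of compound 3 also lie apart by more than the scatter, though no single-point step links them.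

Compound 4, `O=C1O[C@H]([C@@H](O)Cn2cc(CCO)nn2)C(OCc2ccccc2)=C1OCc1ccccc1`, has not yet been measured. It differs from compound 3 in one place: 2-hydroxyethyl in place of 4-methoxyphenyl on an aromatic carbon.

Among the measured compounds shown here, only one measured step touches this position, and it runs the other way: a small group without a ring was exchanged for the 4-methoxyphenyl group, and the number fell modestly, as a 2.0-fold lower number from compound 2 to compound 3 (0.31 log units; beyond the scatter) shows. Compound 4 now removes that same 4-methoxyphenyl group and puts a 2-hydroxyethyl group, also without a ring, in its place. For the measured compounds named here, compound 4 is therefore expected to give a higher number than compound 3, with a step of about a 1.9-fold higher number from compound 3 to compound 4 (0.28 log units; within the scatter), of a size similar to the one seen from compound 2 to compound 3. For compound 4 the estimated value in this assay is 50000 nM, with a range from 25000 nM to 100000 nM.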

Compound 4, half-maximal inhibitory concentration: > 100000 nM
Compound 4: no number, only a limit; the forecaster's own chance of this, stated with the estimate: 10%; at least 2.0-fold (0.30 log units) between middle value and limit.
By their numbers in this assay, from the lowest: compound 3; then compounds 2 and 1 (each within the scatter of the next). At a limit, above all of these: compound 4.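

In this assay the result for compound 4 is a limit and not a number: the limit of > 100000 nM in this assay, at which 1 of the 4 values shown sits.

Among these compounds, it shows that this aromatic carbon does not tolerate every exchange, as 2-hydroxyethyl in place of 4-methoxyphenyl gives an at least 3.8-fold higher number from compound 3 to compound 4 (0.58 log units; beyond the scatter), whereas the only earlier step at this position was a 2.0-fold lower number from compound 2 to compound 3 (0.31 log units; beyond the scatter). The result separates compound 4 clearly only from compound 3, since the floors of an at least 1.9-fold higher number from compound 2 to compound 4 (0.27 log units; that floor lies within the scatter) and an at least 1.7-fold higher number from compound 1 to compound 4 (0.23 log units; that floor lies within the scatter) both lie within the scatter, and neither step alone sets compound 4 firmly apart.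

As far as these compounds go, how far compound 4 lies beyond its limit remains open, and so does the full size of the step from compound 3. The change also removes the ring and brings in a hydroxyl group at once, so the compounds shown cannot tell which of the two goes with the higher number; a plain phenyl group, an ethyl chain without the hydroxyl, or an amine on the same carbon would each bear on that question.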